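Positional shift of the methyl on the pendant aryl

This account rests on a few compounds, and the source may have more. Where it says the series, first, only, none or still open, it means among the compounds named here.

Compound 3 `COc1cc(-n2cnc3ccc(-c4cccc(C)c4)cc32)cc(OC)c1OC` gives 360 nM in a functional assay on MCF7 cells (Homo sapiens) for antiproliferative activity, read by MTT assay, with a stated time of 72 h (a higher number here means a weaker inhibitor, a lower number a stronger inhibitor), the lowest of the three numbers recorded. Its nearest neighbour is compound 1 `COc1cccc(-c2ccc3ncn(-c4cc(OC)c(OC)c(OC)c4)c3c2)c1`, which gives 1610 nM, and the step is a 4.5-fold lower number from compound 1 to compound 3 (0.65 log units; beyond the scatter). Compound 2 `COc1cc(-n2cnc3ccc(-c4ccc(Cl)cc4Cl)cc32)cc(OC)c1OC` gives 5420 nM, and the step is a 15-fold lower number from compound 2 to compound 3 (1.18 log units; beyond the scatter). Both measured steps therefore concern the identity of the substituent on the pendant aryl ring, not where a given substituent sits on it.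

Compound 4 `COc1cc(-n2cnc3ccc(-c4ccc(C)cc4)cc32)cc(OC)c1OC` differs from compound 3 by 4-methylphenyl in place of 3-methylphenyl on an aromatic carbon. For the measured compounds named here, no measured step addresses a move of the same group from one position to another on this ring; the two steps that touch the ring, a 4.5-fold lower number from compound 1 to compound 3 (0.65 log units; beyond the scatter) and a 15-fold lower number from compound 2 to compound 3 (1.18 log units; beyond the scatter), were modest and large, but both changed the group itself. A step for compound 4 is expected to be small, within or just beyond the scatter, and more likely towards a higher number given that compound 3 already stands lowest. The estimate for compound 4 is 550 nM, with a range of 200 nM to 1500 nM, corresponding to an expected step of a 1.5-fold higher number from compound 3 to compound 4 (0.18 log units; within the scatter).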

Compound 4, half-maximal inhibitory concentration: 110 nM
Estimate against measurement, compound 4: 5.0-fold (0.70 log units) above; the whole stated range lies above it.
By their numbers in this assay, from the lowest: compound 4; then compound 3; then compound 1; then compound 2.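

In this assay, moving the methyl from 3-methylphenyl to 4-methylphenyl gives a 3.3-fold lower number from compound 3 to compound 4 (0.51 log units; beyond the scatter), so with the same atoms on both sides, the placement of the group on the pendant ring matters as well as its identity. The 4-methylphenyl group also widens the gaps to the other two aryl groups, with a 15-fold lower number from compound 1 to compound 4 (1.17 log units; beyond the scatter) and a 49-fold lower number from compound 2 to compound 4 (1.69 log units; beyond the scatter), leaving compound 4 lowest of the four numbers. No measurement at hand explains why this shift of the methyl lowers the number.

On these data alone, the effect of a shift is seen for methyl alone, so whether the methoxy group of compound 1 would respond in the same way stays open. Also open, as far as these compounds go, is whether an ethyl group, an amine or a carboxylic acid in place of the methyl of compound 4 would keep the number this low.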